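The source may report more compounds than this note shows. Statements on the series, on what has been measured and on what is new or still open speak of the compounds shown alone.

Working notes on the series. Within the data shown here, compound 1 `CCc1cccc2c(O)c(-c3occ(C)c3C(=O)O)ccc12` is the one member measured so far that returns a number in a functional assay on KB cells (Homo sapiens) for cytotoxicity, read by MTT assay, with a stated time of 72 h; on this read-out higher numbers stand for an effect only at larger amounts of compound and lower numbers for an effect already at smaller amounts: compound 1 gives 9.1 ug/mL. Compound 2 `CCCOC(=O)c1c(C)coc1-c1ccc2c(CC)cccc2c1OC` reaches only a limit of the assay in this assay, namely > 10 ug/mL. Compound 3 `CCOc1c(-c2occ(C)c2CO)ccc2c(CC)cccc12` likewise returns a limit, > 10 ug/mL. Compound 2 therefore stands at the limit of > 10 ug/mL in this assay, at which 2 of the 3 values shown sit, without a number of its own. Compound 4 `CCc1cccc2c(OC)c(-c3occ(C)c3COCC(F)(F)F)ccc12` is not yet measured; relative to compound 2 the change is (2,2,2-trifluoroethoxy)methyl in place of propoxycarbonyl on an aromatic carbon. Among the measured compounds shown here, no step between measured compounds exists, so the size of this move cannot be read from the data. The expected step is a step that the limit leaves unreadable from compound 2 to compound 4, none beyond the scatter. Compound 4 is estimated at 15 ug/mL, range 5 ug/mL to 40 ug/mL, most likely again a limit.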

Compound 4, concentration for half-maximal effect: 6.6 ug/mL
For compound 4 the middle estimate is 2.3-fold (0.36 log units) above the measured one; the range from low to high includes it.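

In this assay compound 4 gives 6.6 ug/mL as a number, with (2,2,2-trifluoroethoxy)methyl on this aromatic carbon of the five-membered ring. Compound 2 holds only > 10 ug/mL as a limit of the assay, not a number. The change in place of propoxycarbonyl therefore gives an at least 1.5-fold lower number from compound 2 to compound 4 (0.18 log units; that floor lies within the scatter), so a real shift at this position is not established.

Still open, as far as these compounds go, is the true size of this step. Also open, from the compounds shown here alone, is how a primary amine or a plain ethoxymethyl chain at this position would read in this assay.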